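The source may hold more compounds than are shown below. What is called first, only, known or untested is meant among the compounds shown, and "the series" means these compounds.

In a functional assay on OVCAR-4 cells (Homo sapiens) for inhibition, read by sulforhodamine B assay, with a stated time of 48 h (on this read-out lower numbers stand for stronger inhibition of growth and higher numbers for weaker inhibition of growth), compound 1 (`CN(C)/C=C/C(=O)c1nn(-c2ccccc2)c(-c2ccccc2)c1C#N`) gives 63800 nM, compound 2 (`N#Cc1c(-c2nnc(O)c3nn(-c4ccccc4)cc23)nn(-c2ccccc2)c1-c1ccccc1`) gives 26400 nM, and compound 3 (`N#Cc1c(-c2nnc(O)c3nn(-c4ccc(Cl)cc4)cc23)nn(-c2ccccc2)c1-c1ccccc1`) gives 4380 nM. That makes compound 3 the strongest growth inhibitor of the three, with the lowest number, and its gaps to both of the others lie beyond the usual scatter.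

The next compound to consider is compound 4 (`N#Cc1c(-c2nnc(-c3ccccc3)c3nn(-c4ccc(Cl)cc4)cc23)nn(-c2ccccc2)c1-c1ccccc1`), which keeps the chloro group of compound 3 and has phenyl in place of hydroxy on an aromatic carbon. For the measured compounds named here, this is a much larger change than swapping a single atom, and no measured pair shows what happens when the hydroxy is replaced.

Going by the values given here, the only measured step that offers any guide is a 6.0-fold lower number from compound 2 to compound 3 (0.78 log units; beyond the scatter), a modest gain from chloro in place of hydrogen at a different place in the molecule. It therefore hints at the size of step to expect, but it says little about direction. A modest step towards a lower number is a tentative expectation, and a step the other way cannot be ruled out.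

In this assay, the expected step is a 2.2-fold lower number from compound 3 to compound 4 (0.34 log units; beyond the scatter). For compound 4, the estimated value is 2000 nM, with an expected range from 500 nM to 8000 nM.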

Compound 4, concentration for 50% growth inhibition: 7660 nM
Estimate against measurement, compound 4: 3.8-fold (0.58 log units) below; measured number inside the range.
By their numbers in this assay, from the lowest: compounds 3 and 4 (each within the scatter of the next); then compound 2; then compound 1.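

In this assay, putting phenyl in place of hydroxy on this aromatic carbon, next to the ring nitrogen, gives a 1.7-fold higher number from compound 3 to compound 4 (0.24 log units; within the scatter), so the two compounds cannot be told apart on this read-out. The earlier compounds shown here with this ring system all carry hydroxy here and so say nothing about this position, whereas this pair shows that a much larger group, with six heavy atoms in place of one and no hydrogen-bond donor or acceptor, can sit here without a change beyond the scatter when the chloro group stays in place. No measurement bears on why hydroxy and phenyl read alike here.

This single pair does not show how far the position's tolerance extends: an amine, a methyl group, a carboxylic acid or a phenyl ring carrying its own substituent could each read differently. It also leaves open whether phenyl would read the same way in a compound without the chloro group, and one exchange at one position cannot establish a general pattern.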